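A Small Ring in Place of a Methyl on the Amide

A few compounds are considered here, and "the series" means these few. Any claim that something is new, unique, unknown or untested is made for them only; others in the source may bear on it.

Of the compounds shown here, three sharing one core have been measured in a physicochemical assay for solubility, read by HPLC; on this read-out higher numbers stand for higher solubility and lower numbers for lower solubility. Compound 2 `CC(=O)N1CCN(c2nc(=O)c3cc(C(F)(F)F)cc([N+](=O)[O-])c3s2)CC1` gives 83.9 ug/mL, the highest of the three numbers. Compound 3 `Cc1ccc(C(=O)N2CCN(c3nc(=O)c4cc(C(F)(F)F)cc([N+](=O)[O-])c4s3)CC2)cc1` gives 6.7 ug/mL, and compound 1 `O=C(CC1CCCCC1)N1CCN(c2nc(=O)c3cc(C(F)(F)F)cc([N+](=O)[O-])c3s2)CC1` gives 0.12 ug/mL. The change from compound 2 to compound 4 `O=C(C1CCC1)N1CCN(c2nc(=O)c3cc(C(F)(F)F)cc([N+](=O)[O-])c3s2)CC1` is cyclobutyl in place of methyl on a carbonyl carbon. For the measured compounds named here, two measured steps bear on it: a larger group on the carbonyl carbon went with a lower number, a 13-fold lower number from compound 2 to compound 3 (1.10 log units; beyond the scatter), and the largest group gave the lowest value, a 56-fold higher number from compound 1 to compound 3 (1.75 log units; beyond the scatter), while a 700-fold higher number from compound 1 to compound 2 (2.84 log units; beyond the scatter) spans the whole range. Cyclobutyl brings more to the carbonyl carbon than methyl but less than the groups of compounds 1 and 3, so a fall is expected that stops short of compound 3. For compound 4 the expected step is a 7.0-fold lower number from compound 2 to compound 4 (0.84 log units; beyond the scatter). Compound 4 is estimated at 12 ug/mL, between 3 ug/mL and 40 ug/mL.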

Compound 4, solubility: 39.3 ug/mL
Compound 4: the middle estimate sits 3.3-fold (0.52 log units) below what was measured, within the range that was stated.
By their numbers in this assay, from the lowest: compound 1; then compound 3; then compound 4; then compound 2.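

In this assay a small ring on the carbonyl carbon changes the number only modestly (a 2.1-fold lower number from compound 2 to compound 4 (0.33 log units; beyond the scatter)), and compound 4 stays well clear of the two compounds with larger groups (a 5.9-fold higher number from compound 3 to compound 4 (0.77 log units; beyond the scatter); a 330-fold higher number from compound 1 to compound 4 (2.52 log units; beyond the scatter)). Going from methyl through cyclobutyl and 4-methylphenyl to cyclohexylmethyl, the number falls at each stage, and none of the four compounds goes against that order. Going by these compounds, how a cyclopropyl, or a cyclobutyl carrying an amine, would read at this position stays open. Nothing shown here explains why cyclobutyl lowers the number so little.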